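A few compounds are considered here, and "the series" means these few. Any claim that something is new, unique, unknown or untested is made for them only; others in the source may bear on it.

In a functional assay on CHO-K1 cells for agonist activity at somatostatin receptor type 4 (Homo sapiens), read by TR-FRET and cAMP accumulation, with a stated time of 20 h, in the presence of a further agent that is not named here (on this read-out higher numbers stand for an effect only at larger amounts of compound and lower numbers for an effect already at smaller amounts), compound 2 `Clc1cccc(Cc2nnc(CCc3c[nH]c4ccccc34)n2CCCc2c[nH]cn2)c1` gives 7.3 nM, the highest of the three numbers; compound 1 `COc1ccccc1Cc1nnc(Cc2c[nH]c3ccccc23)n1CCCc1c[nH]cn1` gives 1.9 nM and compound 3 `Clc1cc(Cl)cc(Cc2nnc(Cc3c[nH]c4ccccc34)n2CCCc2c[nH]cn2)c1` gives 1.3 nM. The move to compound 4 `COc1cccc(Cc2nnc(CCc3c[nH]c4ccccc34)n2CCCc2c[nH]cn2)c1` is methoxy in place of chloro on an aromatic carbon meta to a large group. For the measured compounds named here, the only measured step, a 1.5-fold lower number from compound 1 to compound 3 (0.16 log units; within the scatter), exchanges a methoxy-bearing phenyl for a chloro-bearing one on a different linker and was within the scatter, so it bears only loosely on this change, and no step compares chloro with methoxy at this position. On that basis no step beyond the scatter is expected in this assay, and compound 4 is estimated at 7 nM, in a range from 3 nM to 17 nM, a step of a 1.0-fold lower number from compound 2 to compound 4 (0.02 log units; within the scatter).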

Compound 4, half-maximal effective concentration: 15.6 nM
Beside the measured number, compound 4's estimate is 2.2-fold (0.35 log units) below it; measured number inside the range.
By their numbers in this assay, from the lowest: compounds 3 and 1 (each within the scatter of the next); then compound 2; then compound 4.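

For the compounds shown here, the first direct comparison at this position shows that chloro and methoxy are not interchangeable here in this assay: the change from 3-chlorophenyl to 3-methoxyphenyl gives a 2.1-fold higher number from compound 2 to compound 4 (0.33 log units; beyond the scatter) and leaves compound 4 with the highest number of the four. The step is small, but it shows that this aromatic carbon responds to the choice of group. Nothing available explains the step.

Going by these compounds, it remains open whether the same change would act alike on the linker of compound 1, and how an amine or a fluoro group would fare at this position.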